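The source may report more compounds than this note shows. Statements on the series, on what has been measured and on what is new or still open speak of the compounds shown alone.

Of the compounds shown here, three that share a core have been measured in an assay on RBL-1 cells with Polyunsaturated fatty acid 5-lipoxygenase (Rattus norvegicus) as the target; on this read-out lower numbers stand for stronger inhibition and higher numbers for weaker inhibition. Compound 1, `CC(C)(C)c1ccc2ccccc2c1O`, gives 180 nM. Compound 2, `Cc1ccc(Cc2ccc3ccccc3c2O)cc1`, gives 24 nM. Compound 3, `Oc1c(Cc2cccnc2)ccc2ccccc12`, gives 230 nM. Among these three numbers compound 2 stands lowest; compound 1 lies nearest to it, and compound 3 lies furthest from it, and in both cases the gap is beyond the usual scatter of repeated measurements, so compound 2 is the most potent of the three.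

Compound 4, `COc1ccc(Cc2ccc3ccccc3c2O)cc1`, has not yet been measured. It differs from compound 2 in one place: methoxy in place of methyl on an aromatic carbon. The group that leaves and the group that enters are both small, both free of rings and without net charge; the entering group brings one additional heavy atom and one hydrogen-bond acceptor, sitting on an aromatic carbon of a six-membered aromatic ring of carbon only, para to a large group.

Within the data shown here, no pair of measured compounds shows this kind of exchange, so no measured step exists to lean on. The account expects that the change from compound 2 to compound 4 produces no step beyond the scatter in this assay, with at most a slight drift toward a higher number. For compound 4 the estimated value in this assay is 35 nM, with a likely range from 12 nM to 100 nM, which means an expected step of a 1.5-fold higher number from compound 2 to compound 4 (0.16 log units; within the scatter).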

Compound 4, half-maximal inhibitory concentration: 75 nM
For compound 4 the middle estimate is 2.1-fold (0.33 log units) below the measured one; the measured number falls inside the stated range.
By their numbers in this assay, from the lowest: compound 2; then compound 4; then compounds 1 and 3 (each within the scatter of the next).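

In this assay, among these compounds, methoxy in place of methyl on an aromatic carbon, para to a large group, gives a 3.1-fold higher number from compound 2 to compound 4 (0.49 log units; beyond the scatter) and so provides the first measured step in this set, a modest one toward weaker inhibition that shows this position is not indifferent to the exchange. The entering group brings one additional heavy atom and one hydrogen-bond acceptor, and this single exchange cannot separate the two or tell which of them goes with the step. Nothing measured here speaks to why the number rises.

Only methyl and methoxy are shown at this position, so it remains open whether a chlorine, a hydroxyl or a longer chain such as ethoxy would stay close to compound 2 or fall further from it. The compounds also leave open whether the same exchange would give a step of this size elsewhere on that ring.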